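The source may hold more compounds than are shown below. What is called first, only, known or untested is meant among the compounds shown, and "the series" means these compounds.

Of the compounds shown here, three sharing one core have been tested in a functional assay on OVCAR cells (Homo sapiens) for inhibition, read by MTT assay, with a stated time of 48 h; on this read-out lower numbers stand for stronger inhibition of growth and higher numbers for weaker inhibition of growth. Compound 1, `O=[N+]([O-])c1ccc(-c2cc(-c3ccc(Br)cc3)n[nH]2)cc1`, gives 17500 nM. Compound 2, `COc1ccc(-c2cc(-c3ccc(C(F)(F)F)cc3)n[nH]2)cc1`, gives 22800 nM. Compound 3, `COc1ccc(-c2cc(-c3ccc(F)cc3)n[nH]2)cc1`, gives 14000 nM, the smallest number of the three, although its gaps to compound 1 and to compound 2 both lie within the usual scatter. Among the measured compounds shown here, the only step between compounds differing in one place is a 1.6-fold lower number from compound 2 to compound 3 (0.21 log units; within the scatter). Compound 4, `COc1ccc(-c2cc(-c3ccc(Br)cc3)n[nH]2)cc1`, is not yet measured; it differs from compound 3 by bromo in place of fluoro on an aromatic carbon. For the measured compounds named here, no measured step swaps exactly these two groups; compound 1 also carries bromo, but it differs from compound 3 in a second place as well, so only its value and that of compound 3 can be set side by side. Going by the values given here, since the one known step of a 1.6-fold lower number from compound 2 to compound 3 (0.21 log units; within the scatter) stayed within the scatter, no change beyond the scatter is expected in this assay, and the expected step is a 1.1-fold higher number from compound 3 to compound 4 (0.03 log units; within the scatter). Compound 4 is therefore estimated at 15000 nM, between 7000 nM and 32000 nM.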

Compound 4, concentration for 50% growth inhibition: 20700 nM
Beside the measured number, compound 4's estimate is 1.4-fold (0.14 log units) below it, within the range that was stated.
By their numbers in this assay, from the lowest: compounds 3, 1, 4 and 2 (each within the scatter of the next).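

Bromo on this aromatic carbon can now be set directly against fluoro (a 1.5-fold higher number from compound 3 to compound 4 (0.17 log units; within the scatter)) and against trifluoromethyl (a 1.1-fold lower number from compound 2 to compound 4 (0.04 log units; within the scatter)) in this assay, and these three groups are not told apart there. Elsewhere on the shared core, with bromo kept in place, methoxy in place of nitro gives a first direct reading (a 1.2-fold higher number from compound 1 to compound 4 (0.07 log units; within the scatter)), and these two groups are not told apart either. As far as these compounds go, whether an amine or a carboxylic acid on this carbon would move the number beyond the scatter stays open. Nothing at hand explains why these groups read alike.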